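Replacing isopropyl in compound 3

This account rests on a few compounds, and the source may have more. Where it says the series, first, only, none or still open, it means among the compounds named here.

For the measured compounds named here, in a functional assay (aorta) with Oryctolagus cuniculus as the target (a higher number here means a weaker inhibitor, a lower number a stronger inhibitor), compound 3 (`CC1=NC(C)=C(C(=O)OCCCN2C(=O)c3ccccc3S2(=O)=O)C(c2ccccc2Cl)/C1=C(\O)OC(C)C`) gives 1.3 nM, the lowest number so far. Compound 1 (`CC1=NC(C)=C(C(=O)OCCCN2C(=O)c3ccccc3S2(=O)=O)C(c2cccc([N+](=O)[O-])c2)/C1=C(\O)OCC1CCCO1`) gives 10.5 nM and compound 2 (`CC1=NC(C)=C(C(=O)OCCCN2C(=O)c3ccccc3S2(=O)=O)C(c2ccccc2[N+](=O)[O-])/C1=C(\O)OCC1CCCO1`) gives 6.8 nM. Both of these numbers lie beyond the scatter from that of compound 3. Compound 4 (`CC1=NC(C)=C(C(=O)OCCCN2C(=O)c3ccccc3S2(=O)=O)C(c2ccccc2Cl)/C1=C(\O)OCC1CCCO1`) has (oxolan-2-yl)methyl in place of isopropyl on an oxygen on an unsaturated carbon. Going by the values given here, no measured step isolates this change. Among the compounds with values here, the one measured step, a 1.5-fold lower number from compound 1 to compound 2 (0.19 log units; within the scatter), lies within the scatter and concerns only the nitrophenyl group. Compounds 1 and 2 carry the entering group but also differ from compound 3 in that nitrophenyl group, and compound 2 stands at 6.8 nM, so a higher number is expected. The expected step in this assay is a 3.1-fold higher number from compound 3 to compound 4 (0.49 log units; beyond the scatter). Compound 4 is estimated at 4 nM, with an expected range of 1.5 nM to 10 nM.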

Compound 4, half-maximal inhibitory concentration: 7.1 nM
Compound 4: the middle estimate sits 1.8-fold (0.25 log units) below what was measured; the measured number falls inside the stated range.
By their numbers in this assay, from the lowest: compound 3; then compounds 2, 4 and 1 (each within the scatter of the next).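

In this assay, for the compounds shown here, the step of a 5.5-fold higher number from compound 3 to compound 4 (0.74 log units; beyond the scatter) is the first reading of (oxolan-2-yl)methyl in place of isopropyl with the 2-chlorophenyl group held fixed, and it lies beyond the scatter. With (oxolan-2-yl)methyl held fixed, the aryl changes give a 1.0-fold higher number from compound 2 to compound 4 (0.02 log units; within the scatter) and a 1.5-fold lower number from compound 1 to compound 4 (0.17 log units; within the scatter) and both lie within the scatter, so these three compounds are not separated by their aryl groups. No measurement available here bears on the origin of the isopropyl step.

As far as these compounds go, whether an ethyl or a cyclopentylmethyl group on that oxygen would read closer to compound 3 or to compound 4 remains open. Also open, from the compounds shown here alone, is how isopropyl reads alongside a nitrophenyl group.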